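Pentyl to thiophene-bearing ester: compound 3 to compound 4

The source may report more compounds than this note shows. Statements on the series, on what has been measured and on what is new or still open speak of the compounds shown alone.

In a functional assay on A549 cells (Homo sapiens) for cytotoxicity, read by MTT assay, with a stated time of 48 h (a lower number here means a stronger inhibitor, a higher number a weaker inhibitor), compound 3 `C=C1C(=O)O[C@H]2CC3=C[C@H](C/C(C)=C/[C@@H](OC(=O)CCCCC)[C@H]12)OC3=O` gives only a limit, > 10000 nM. Compound 1 `C=C1C(=O)O[C@H]2CC3=C[C@H](C/C(C)=C/[C@@H](OC(=O)c4ccc([N+](=O)[O-])cc4)[C@H]12)OC3=O` also gives only a limit, > 10000 nM. Compound 2 `C=C1C(=O)O[C@H]2CC3=C[C@H](C/C(C)=C/[C@@H](OC(=O)c4ccc(-c5ccccc5)cc4)[C@H]12)OC3=O` is the one ester of the three with a number, 4600 nM.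

Compound 4 `C=C1C(=O)O[C@H]2CC3=C[C@H](C/C(C)=C/[C@@H](OC(=O)/C=C/c4cccs4)[C@H]12)OC3=O` keeps the shared core and changes the ester group: 2-(thiophen-2-yl)ethenyl in place of pentyl on a carbonyl carbon. The new group is 2-(thiophen-2-yl)ethenyl in place of pentyl on a carbonyl carbon.

Among the measured compounds shown here, two measured steps bear on this place. Phenyl in place of nitro on an aromatic carbon gives an at least 2.1-fold lower number from compound 1 to compound 2 (0.33 log units; beyond the scatter), the only readable step. Pentyl in place of 4-nitrophenyl gives a step that the two limits leave unreadable from compound 1 to compound 3, which has no readable size. Compound 2 at 4600 nM suggests that an aromatic ester can reach a measurable level, but compound 1 at > 10000 nM goes against any such rule. A small lowering is therefore expected, and a result at the limit remains quite possible.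

The expected change is an at least 1.2-fold lower number from compound 3 to compound 4 (0.09 log units; that floor lies within the scatter). The estimate for compound 4 is 8000 nM, with an expected range of 3000 nM to 20000 nM.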

Compound 4, half-maximal inhibitory concentration: 4300 nM
For compound 4 the middle estimate is 1.9-fold (0.27 log units) above the measured one, and the stated range covers the measured number.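

Among the compounds shown here, at the carbonyl carbon of the ester, 2-(thiophen-2-yl)ethenyl in place of pentyl gives an at least 2.3-fold lower number from compound 3 to compound 4 (0.36 log units; beyond the scatter), the first readable step on the pentyl ester, and in place of 4-nitrophenyl it gives an at least 2.3-fold lower number from compound 1 to compound 4 (0.36 log units; beyond the scatter). Both steps are floors rather than sizes because their starting compounds sit at a limit: the limit of > 10000 nM in this assay, at which 2 of the 4 values shown sit. In this assay compound 2 gives 4600 nM and compound 4 gives 4300 nM, so two different ester groups now carry a measurable value, with no order between them.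

On these data alone, the step between compound 1 and compound 3 cannot be read, and the true size of both new steps stays open. The compounds shown also do not separate the thiophene ring from the double bond, and a 2-phenylethenyl ester or a 2-(thiophen-2-yl)ethyl ester would bear on that.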